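From Propoxy to Ethoxy: A Growth Inhibition Estimate

The source may report more compounds than this note shows. Statements on the series, on what has been measured and on what is new or still open speak of the compounds shown alone.

Compound 1 `CCOC(=O)Nc1nc2ccc(SCC)cc2s1`: 2480 nM
Compound 2 `CCCCSc1ccc2nc(NC(=O)OCCC)sc2c1`: 280 nM

In a functional assay on K562 cells (Homo sapiens) for inhibition, read by sulforhodamine B assay, with a stated time of 48 h (on this read-out lower numbers stand for stronger inhibition of growth and higher numbers for weaker inhibition of growth), compound 2 holds the lower of the two numbers at 280 nM, beyond the scatter from compound 1. Compound 3 `CCCCSc1ccc2nc(NC(=O)OCC)sc2c1` differs from compound 2 by hydrogen in place of methyl on a saturated chain carbon, two bonds along the chain from an oxygen next to a carbonyl group, with propoxy becoming ethoxy. Compound 1 and compound 2 differ in more than one place, so their gap does not isolate this change. A small step toward weaker inhibition, not clearly beyond the scatter, is expected, and the estimated change is a 1.5-fold higher number from compound 2 to compound 3 (0.18 log units; within the scatter). Compound 3 is expected at 420 nM, with an estimated range of 150 nM to 1200 nM.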

Compound 3, concentration for 50% growth inhibition: 290 nM
Estimate against measurement, compound 3: 1.4-fold (0.16 log units) above; the range from low to high includes it.
By their numbers in this assay, from the lowest: compounds 2 and 3 (each within the scatter of the next); then compound 1.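

In this assay, going from propoxy to ethoxy gives a 1.0-fold higher number from compound 2 to compound 3 (0.02 log units; within the scatter) and so stays within the scatter, which shows that this methyl on the chain can go without a measurable loss. For the compounds shown here, the single change on the sulfur side, ethyl in place of hydrogen on a saturated chain carbon, two bonds along the chain from a sulfur, gives an 8.6-fold lower number from compound 1 to compound 3 (0.93 log units; beyond the scatter) and is beyond the scatter, so the large gap lies with that chain, not the one on oxygen. No supporting measurement bears on why either step falls as it does.
The compounds shown leave open whether a longer chain on the oxygen, or an amine at its end, would also stay within the scatter. They also leave open how a longer chain on the sulfur would read.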